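This account rests on a few compounds, and the source may have more. Where it says the series, first, only, none or still open, it means among the compounds named here.

Measured compounds:
compound 1 `O=CN1CCN(c2ccc(Cl)cc2)C1=S` — 26900 nM
compound 2 `COc1cc(C(=O)N2CCN(C=O)C2=S)cc(OC)c1OC` — 29300 nM

Both numbers come from a functional assay on SF-295 cells (Homo sapiens) for inhibition, read by sulforhodamine B assay, with a stated time of 48 h; on this read-out higher numbers stand for weaker inhibition of growth and lower numbers for stronger inhibition of growth. In this assay compound 1 gives 26900 nM, and compound 2 gives 29300 nM. The two values sit within the scatter of each other, so nothing separates compound 1 from compound 2 on these two numbers; compound 1 is simply one of two compounds that sit close together at the weak end of the range.

Compound 3 `O=CN1CCN(c2ccc(Cl)c(Cl)c2)C1=S` has not been measured yet. It differs from compound 1 in one place: chloro in place of hydrogen on an aromatic carbon. No step between two measured compounds is known for this series, so the size of the effect of a second chloro on the ring cannot be read from any shown pair. With a single chloro on this ring already giving 26900 nM for compound 1, the second chloro is expected to move the number little, if at all, and any move is more likely downward than upward; the expected step from compound 1 to compound 3 is a 1.3-fold lower number from compound 1 to compound 3 (0.13 log units; within the scatter), not beyond the scatter. Compound 3 is therefore estimated at 20000 nM, with a range of 8000 nM to 50000 nM.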

Compound 3, concentration for 50% growth inhibition: 18000 nM
For compound 3 the middle estimate is 1.1-fold (0.05 log units) above the measured one, within the range that was stated.
By their numbers in this assay, from the lowest: compounds 3, 1 and 2 (each within the scatter of the next).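

In this assay, within the data shown here, the only step between measured compounds is a 1.5-fold lower number from compound 1 to compound 3 (0.17 log units; within the scatter), for chloro in place of hydrogen on an aromatic carbon, ortho to a chloro group and meta to a group of 8 heavy atoms. This place on the ring therefore takes a chloro without a step that stands clear of the scatter, so this single pair supports neither a gain nor a loss in growth inhibition from the change. The data shown offer no measurement that could explain the size of this step.

As far as these compounds go, whether a methoxy group, an amine or a carboxylic acid at this same place would give a step beyond the scatter remains open. Also open, from the compounds shown here alone, is whether chloro in place of hydrogen would give a step of similar size on the aromatic ring of compound 2, where the surrounding groups differ.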